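Urea aryl to cyclohexyl swap on a shared core

The compounds below may be only part of what the source reports. "The series", "measured", "known", "first", "only" and "open" are said of these compounds alone.

The series shares the core of compound 1 `COc1ccc(NC(=O)Nc2cccc(CNc3nccnc3Cl)c2)cc1`, which in a functional assay on HepG2 cells (Homo sapiens) for antiproliferative activity, read by MTT assay, with a stated time of 48 h (on this read-out lower numbers stand for stronger inhibition and higher numbers for weaker inhibition), gives compound 1 a value of 12000 nM. Compound 3 `Cc1ccc(NC(=O)Nc2cccc(CNc3nccnc3Cl)c2)cc1C` gives 10700 nM in this assay, and the step of a 1.1-fold lower number from compound 1 to compound 3 (0.05 log units; within the scatter) lies within the scatter. Within the data shown here, compound 2 `CN(C)c1ccc(NC(=O)Nc2cccc(CNc3nccnc3Cl)c2)cc1` is the one member for which only a limit is known: in this assay compound 2 gives > 40000 nM, a limit of the assay and not a number, as recorded in the limit of > 40000 nM in this assay, at which 1 of the 3 values shown sits. Relative to its neighbours, compound 2 therefore stands at the weak end of what is shown, with an at least 3.3-fold higher number from compound 1 to compound 2 (0.52 log units; beyond the scatter) and an at least 3.7-fold lower number from compound 2 to compound 3 (0.57 log units; beyond the scatter) both beyond the scatter.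

Compound 4 `O=C(Nc1cccc(CNc2nccnc2Cl)c1)NC1CCCCC1` is not yet measured. It differs from compound 2 by cyclohexyl in place of 4-(dimethylamino)phenyl on an amide-type nitrogen. Among the measured compounds shown here, no measured step exchanges an aryl group for a saturated ring on this nitrogen; the two steps that touch compound 2 both swap one aryl for another and both move the number back below the limit by at least a modest amount. On that basis a step of comparable size is expected for an at least 2.6-fold lower number from compound 2 to compound 4 (0.42 log units; beyond the scatter), returning to the range of compound 1 and compound 3 rather than going lower. Compound 4 is thus expected to give about 15000 nM in this assay, within roughly 5000 nM to 45000 nM, with a real chance that only a limit is again reported.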

Compound 4, half-maximal inhibitory concentration: > 40000 nM
Compound 4 gave a limit, no number (the forecaster's own chance of this, stated with the estimate: 30%); at least 2.6-fold (0.42 log units) between middle value and limit.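

In this assay, among these compounds, compound 4 stands at a limit and not a number, and the series now has two such members: the limit of > 40000 nM in this assay, at which 2 of the 4 values shown sit. The exchange of an aryl group for cyclohexyl on the amide-type nitrogen, which no earlier step covered, raises the number against both aryl ureas that have a measured value, with an at least 3.7-fold higher number from compound 3 to compound 4 (0.57 log units; beyond the scatter) and with an at least 3.3-fold higher number from compound 1 to compound 4 (0.52 log units; beyond the scatter). The step between compound 2 and compound 4 cannot be read, as both values are limits, so cyclohexyl joins 4-(dimethylamino)phenyl at the weak end of the series without any order between them, while 4-methoxyphenyl and 3,4-dimethylphenyl keep measurable values.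

The compounds shown do not separate the loss of the aromatic ring from the identity of cyclohexyl itself, a question that an unsubstituted phenyl, a benzyl or a smaller saturated ring such as cyclopentyl on this nitrogen would bear on. On these data alone, how far past the limit compound 2 and compound 4 truly lie also remains open, so the real size of the cyclohexyl change is known only as a minimum.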